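The source may report more compounds than this note shows. Statements on the series, on what has been measured and on what is new or still open speak of the compounds shown alone.

Compound 1 `CN(C)c1ccc(/C=C2/SC(N(c3ccccc3)c3ccccc3)=NC2=O)cc1` was tested in an ADME assay on cells (Homo sapiens) for cytotoxicity, read by sulforhodamine B assay, with a stated time of 48 h; on this read-out lower numbers stand for an effect already at smaller amounts and higher numbers for an effect only at larger amounts of compound. In this assay compound 1 gives only a limit, > 100000 nM, and not a measured number. Two close relatives of compound 1 were tested alongside it. Compound 2 `CCN(CC)c1ccc(/C=C2/SC(N(c3ccccc3)c3ccccc3)=NC2=O)cc1` carries diethylamino in place of dimethylamino on an aromatic carbon, and in this assay compound 2 also gives only a limit, > 100000 nM. Compound 3 `O=C1N=C(N(c2ccccc2)c2ccccc2)S/C1=C/c1ccc(N2CCNCC2)cc1` carries piperazin-1-yl in place of dimethylamino on an aromatic carbon, and in this assay compound 3 again gives only a limit, > 100000 nM. Accordingly the steps a step that the two limits leave unreadable from compound 1 to compound 2, a step that the two limits leave unreadable from compound 1 to compound 3 and a step that the two limits leave unreadable from compound 2 to compound 3 cannot be read, because all three compounds sit at the limit of > 100000 nM in this assay, at which 3 of the 3 values shown sit.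

Compound 4 `CN(C)c1ccc(/C=C2/SC(N(C)c3ccccc3)=NC2=O)cc1` is not yet measured. It differs from compound 1 in one place: methyl in place of phenyl on a nitrogen on an aromatic ring. Within the data shown here, none of the measured steps touches this nitrogen, and none of them shows a readable size, so they give no direction for the change from compound 1 to compound 4. What they do show is that three compounds sharing the core of compound 1 all fall at the limit. The step that the limit leaves unreadable from compound 1 to compound 4 is therefore expected to stay within the scatter. In this assay compound 4 is expected to give 150000 nM, between 60000 nM and 400000 nM, most likely reported again only as a limit.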

Compound 4, half-maximal effective concentration: > 100000 nM
Compound 4 gave a limit, no number; the forecaster's own chance of this, stated with the estimate: 80%; the middle value is on the limit's open side.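

In this assay no new step can be read, because compound 1 and compound 4 give no measured number and sit at one shared limit: (the limit of > 100000 nM in this assay, at which 4 of the 4 values shown sit). The compounds shown leave open at what amount, if any, the shared core acts on these cells, and how much methyl in place of phenyl would change that amount.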